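A few compounds are considered here, and "the series" means these few. Any claim that something is new, unique, unknown or untested is made for them only; others in the source may bear on it.

Measured compounds in an assay on isolated protein for binding affinity to 5-hydroxytryptamine receptor 1B (Rattus norvegicus); a higher number here means a weaker inhibitor, a lower number a stronger inhibitor:
- compound 1, `c1ccc2c(c1)CC2CCCCN1CCN(c2cccc3c2OCCO3)CC1`, this assay 631 nM
- compound 2, `c1ccc2c(c1)CCCCC2CCN1CCN(c2cccc3c2OCCO3)CC1`, this assay 776 nM
- compound 3, `C1=C(CCN2CCN(c3cccc4c3OCCO4)CC2)c2ccccc2C1`, this assay 251 nM

Compound 1 gives the second highest number of the three. Compound 2 sits nearest to it, and the gap between compound 1 and compound 2 lies within the usual scatter, so the two cannot be ranked against each other. Compound 3 stands furthest off, with a lower number than compound 1, and that gap lies beyond the scatter. Among the measured compounds shown here, no step between two measured compounds that differ in a single place is available in this set, so there is no measured reference step to lean on.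

Compound 4, `Clc1cccc2c1CC2CCCN1CCN(c2cccc3c2OCCO3)CC1`, has not been measured in this assay. Its relation to compound 1 is a group of 9 heavy atoms (8 carbon, 1 chlorine; one four-membered non-aromatic ring of carbon only, one six-membered aromatic ring of carbon only) in place of a group of 9 heavy atoms (9 carbon; one four-membered non-aromatic ring of carbon only, one six-membered aromatic ring of carbon only), on a saturated chain carbon, three bonds along the chain from an amine nitrogen in a ring.

With no measured step of this kind in hand, the expectation for compound 4 rests only on the spread of the three measured values, which lie close together. The step from compound 1 to compound 4 is expected to be small, in no definite direction, and probably not beyond the scatter: a 1.3-fold lower number from compound 1 to compound 4 (0.10 log units; within the scatter). For compound 4 the estimated number in this assay is 500 nM, with a range from 200 nM to 1500 nM.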

Compound 4, inhibition constant: 1100 nM
For compound 4 the middle estimate is 2.2-fold (0.34 log units) below the measured one; the measured number falls inside the stated range.
By their numbers in this assay, from the lowest: compound 3; then compounds 1, 2 and 4 (each within the scatter of the next).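

Among the compounds shown here, this is the first measured step at this place, on a saturated chain carbon, three bonds along the chain from an amine nitrogen in a ring: in this assay, the group of 9 heavy atoms (8 carbon, 1 chlorine) in place of the group of 9 heavy atoms (9 carbon) gives a 1.7-fold higher number from compound 1 to compound 4 (0.24 log units; within the scatter), and the two compounds cannot be ranked against each other. The exchange keeps the count of 9 heavy atoms and the same four-membered and six-membered rings, and neither group carries hydrogen-bond donors or acceptors or a net charge, so at this place in the series a chlorine-bearing group of this kind is read as tolerated within the scatter of this assay on the evidence of this one pair. No measurement shown here accounts for the size of this step.

For the compounds shown here, one step cannot show how much the chlorine contributes apart from the rest of the exchanged group, since the two groups differ as wholes and no other pair at this place is available. As far as these compounds go, whether a fluorine, a bromine or a methoxy group in the chlorine's stead, or a longer chain at the same carbon, would move the number beyond the scatter remains open.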